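The source may hold more compounds than are shown below. What is called first, only, known or untested is meant among the compounds shown, and "the series" means these compounds.

Working notes on the series. The shared core is that of compound 1 `CC(=O)O[C@@H]1C[C@@H](OC(=O)c2ccccc2)/C(C)=C/[C@H]2[C@@H](OC(=O)c3ccccc3)[C@@H](C)[C@H](OC(C)=O)[C@]2(OC(C)=O)[C@H](O)[C@](C)(O)/C=C/C1(C)C`. In an ADME assay on NCI/ADR-RES cells (Homo sapiens) for inhibition, read by MTT assay, with a stated time of 48 h (a higher number here means a weaker inhibitor, a lower number a stronger inhibitor), compound 1 gives only a limit of the assay, > 150000 nM. Compound 2 `CC(=O)O[C@@H]1C[C@@H](OC(=O)c2ccccc2)/C(C)=C/[C@H]2[C@@H](OC(=O)c3ccccc3)[C@@H](C)[C@H](OS(=O)(=O)c3ccc(C)cc3)[C@]2(OC(C)=O)[C@H](O)[C@](C)(O)/C=C/C1(C)C` carries (4-methylphenyl)sulfonyl in place of acetyl on an oxygen on a saturated carbon. In this assay compound 2 likewise gives only a limit, > 150000 nM. The step that the two limits leave unreadable from compound 1 to compound 2 therefore cannot be read, since both values sit at the limit of > 150000 nM in this assay, at which 2 of the 2 values shown sit. On the numbers shown compound 2 stands at that limit with no number of its own, and the one further value shown is a limit as well.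

Compound 3 `CC(=O)O[C@@H]1C[C@@H](OC(=O)c2ccccc2)/C(C)=C/[C@H]2[C@@H](OC(=O)c3ccccc3)[C@@H](C)[C@H](OC(=O)c3ccco3)[C@]2(OC(C)=O)[C@H](O)[C@](C)(O)/C=C/C1(C)C` is not yet measured. It differs from compound 2 as follows: (furan-2-yl)carbonyl in place of (4-methylphenyl)sulfonyl on an oxygen on a saturated carbon. Among the compounds with values here, only the step from compound 1 to compound 2 bears on this change, and its size is not readable. Because the two values shown both sit at the limit of > 150000 nM in this assay, at which 2 of the 2 values shown sit, no step beyond the scatter is expected in either direction, and a limit is the likeliest outcome for compound 3 too. Compound 3 is expected at 200000 nM, in the range 100000 nM to 400000 nM. The step that the limit leaves unreadable from compound 2 to compound 3 that this estimate means is expected to be of no consequence.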

Compound 3, half-maximal inhibitory concentration: > 150000 nM
Compound 3: no number, only a limit (the forecaster's own chance of this, stated with the estimate: 80%); the middle value lies beyond the limit too.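

In this assay compound 3 gives > 150000 nM, which is a limit and not a number. Within the data shown here, no step among compound 1, compound 2 and compound 3 can be read, since all values share that limit: the limit of > 150000 nM in this assay, at which 3 of the 3 values shown sit. The compounds shown leave open what value any of the three has beyond the limit, and whether any of these groups on this oxygen changes it.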